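The source may report more compounds than this note shows. Statements on the series, on what has been measured and on what is new or still open speak of the compounds shown alone.

Measured so far in an assay on CHO cells for displacement of a labelled ligand from adenosine receptor A3 (Homo sapiens), read by scintillation counting, with a stated time of 60 min; a higher number here means a weaker inhibitor, a lower number a stronger inhibitor:
Compound 1 `CNC(=O)[C@@]12C[C@@H]1[C@@H](n1cnc3c(NC)nc(C#Cc4ccc(CO)cc4)nc31)[C@H](O)[C@@H]2O` gives 2.16 nM.
Compound 2 `CNC(=O)[C@@]12C[C@@H]1[C@@H](n1cnc3c(NC)nc(C#Cc4cnn(C)c4)nc31)[C@H](O)[C@@H]2O` gives 2.34 nM.

Within the data shown here, compound 2 stands next to compound 1 on these two numbers; the single step between them, a 1.1-fold higher number from compound 1 to compound 2 (0.03 log units; within the scatter), is within the scatter, so the two cannot be ordered on this assay.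

Compound 3 `CNC(=O)[C@@]12C[C@@H]1[C@@H](n1cnc3c(NC)nc(C#Cc4cc(C)c(C)o4)nc31)[C@H](O)[C@@H]2O` has not been measured. It differs from compound 2 by 4,5-dimethylfuran-2-yl in place of 1-methyl-1H-pyrazol-4-yl on a triple-bonded carbon. Among the measured compounds shown here, the only measured step that bears on this kind of change is the swap of the group on the triple-bonded carbon from compound 1 to compound 2, a 1.1-fold higher number from compound 1 to compound 2 (0.03 log units; within the scatter), which did not move the number beyond the scatter. On that basis the aryl group on the triple-bonded carbon appears tolerant of exchange within the two compounds seen, and for compound 3 a step of a 1.1-fold higher number from compound 2 to compound 3 (0.05 log units; within the scatter) is expected, that is, none beyond the scatter. Compound 3 is therefore estimated at 2.6 nM in this assay, with a range of 1 nM to 7 nM.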

Compound 3, inhibition constant: 1.45 nM
The estimate for compound 3 lay 1.8-fold (0.25 log units) above the measured number, and the stated range covers the measured number.
By their numbers in this assay, from the lowest: compounds 3, 1 and 2 (each within the scatter of the next).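

In this assay, 4,5-dimethylfuran-2-yl in place of 1-methyl-1H-pyrazol-4-yl gives a 1.6-fold lower number from compound 2 to compound 3 (0.21 log units; within the scatter), and in place of 4-(hydroxymethyl)phenyl it gives a 1.5-fold lower number from compound 1 to compound 3 (0.17 log units; within the scatter). A third aromatic group on the triple-bonded carbon therefore keeps the number within the scatter of both earlier compounds, extending the tolerance seen so far to a ring with one hetero atom and one hydrogen-bond acceptor, against two of each in the 1-methyl-1H-pyrazol-4-yl group. No supporting data bear on why these exchanges leave the number within the scatter.

Going by these compounds, all three groups here are aromatic rings, so it remains open how an aminomethyl group, a carboxylic acid, a cyclohexyl ring or a longer alkyl chain on the triple-bonded carbon would fare. Also open, on these data alone, is whether this tolerance holds at any other adenosine receptor, since the three compounds are compared only in this assay.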